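From a 4-cyanophenyl to a 3-hydroxyphenyl group

The source may report more compounds than this note shows. Statements on the series, on what has been measured and on what is new or still open speak of the compounds shown alone.

Among the measured compounds shown here, in a physicochemical assay for lipophilicity, measured as octanol-water partition (on this read-out lower numbers stand for lower lipophilicity and higher numbers for higher lipophilicity), compound 1 `CC1=C(C(=O)OCc2cccnc2)C(c2ccc(C#N)cc2)C2=C(CCCC2=O)N1` gives 1.36, the lowest of the three numbers measured so far. Compound 2 `CCCC1C(C(=O)OCc2ccccn2)=C(C)NC2=C1C(=O)CCC2` gives 2.6 and compound 3 `CC1=C(C(=O)OCc2ccccn2)C(c2ccc(Br)cc2)C2=C(CCCC2=O)N1` gives 2.42, two numbers within the scatter of each other and both clearly beyond the scatter from compound 1.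

The next compound, compound 4 `CC1=C(C(=O)OCc2cccnc2)C(c2cccc(O)c2)C2=C(CCCC2=O)N1`, keeps the core of compound 1 and its ((pyridin-3-yl)methoxy)carbonyl group. It differs in one place, with 3-hydroxyphenyl in place of 4-cyanophenyl on a saturated ring carbon.

For the measured compounds named here, only one measured step changes a group on such a carbon. This is a number 0.18 log units lower from compound 2 to compound 3 (within the scatter), where 4-bromophenyl replaces propyl. Going by the values given here, that step is small, but it involves neither group of the present swap, and no measured step removes 4-cyanophenyl or brings in 3-hydroxyphenyl. It therefore gives no size to carry over, and no shift beyond the scatter can be argued from these data. The expectation stays anchored on compound 1 at 1.36, and the range is kept wide. What is expected is a number 0.04 log units higher from compound 1 to compound 4 (within the scatter). The estimated value for compound 4 is 1.4, with an expected range from 0.8 to 2.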

Compound 4, partition coefficient: 1.21
Compound 4: the middle estimate sits 0.19 log units above what was measured; low and high end bracket the measured number.
By their numbers in this assay, from the lowest: compounds 4 and 1 (each within the scatter of the next); then compounds 3 and 2 (each within the scatter of the next).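

In this assay, the swap on this saturated ring carbon gives a number 0.15 log units lower from compound 1 to compound 4 (within the scatter), so compound 1 and compound 4 cannot be told apart, even though 3-hydroxyphenyl brings a hydrogen-bond donor that 4-cyanophenyl lacks. Among the compounds shown here, the only earlier step at this kind of carbon, a number 0.18 log units lower from compound 2 to compound 3 (within the scatter), also stays within the scatter, but it exchanges a propyl chain for an aromatic ring; the new step is the first to exchange one substituted phenyl ring for another, and the first at this carbon with the ((pyridin-3-yl)methoxy)carbonyl group in place. Both measured steps at this carbon are therefore small, and neither compound pair goes against that, though two steps are a thin basis. (Nothing available explains why the numbers stay so close)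

Still open, as far as these compounds go, is whether a phenyl ring carrying a carboxylic acid or an amine, or a chain longer than propyl, would move the number beyond the scatter at this carbon. Also open, from the compounds shown here alone, is whether 3-hydroxyphenyl and 4-cyanophenyl would stay this close with a different group in place of the ((pyridin-3-yl)methoxy)carbonyl group.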